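Fluoro to methyl from compound 3 to compound 4

The compounds below may be only part of what the source reports. "The series", "measured", "known", "first", "only" and "open" are said of these compounds alone.

- compound 1 `Cc1c(CNCc2ccccc2)cc(-c2ccc(Cl)cc2)n1-c1ccc(Cl)cc1`: "not determined" (no result reported)
- compound 2 `Cc1cc(/C=N\OCc2ccccc2)c(C)n1-c1ccc(Cl)cc1`: 128 ug/mL
- compound 3 `Cc1cc(CNCc2ccc(F)cc2)c(C)n1-c1ccc(Cl)cc1`: 26 ug/mL

In an ADME assay on RAW264.7 cells (Mus musculus) for cytotoxicity, read by trypan blue exclusion, with a stated time of 48 h (a higher number here means a weaker inhibitor of growth, a lower number a stronger inhibitor of growth), compound 3 gives 26 ug/mL, the lowest of the two numbers available. Compound 2 stands higher at 128 ug/mL, a gap beyond the usual scatter, while compound 1 has no result.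

Compound 4 `Cc1ccc(CNCc2cc(C)n(-c3ccc(Cl)cc3)c2C)cc1` differs from compound 3 by methyl in place of fluoro on an aromatic carbon, para to a large group, so 4-fluorobenzyl becomes 4-methylbenzyl. Within the data shown here, no measured pair shows this change, so the expectation starts from compound 3 at 26 ug/mL. In this assay, no step beyond the scatter is expected, and the estimated step of a 1.1-fold higher number from compound 3 to compound 4 (0.03 log units; within the scatter) is small. Compound 4 is estimated at 28 ug/mL, within a range of 12 ug/mL to 65 ug/mL.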

Compound 4, concentration for 50% growth inhibition: 0.1 ug/mL
For compound 4 the middle estimate is 280-fold (2.45 log units) above the measured one; the measured number lies below the stated range.
By their numbers in this assay, from the lowest: compound 4; then compound 3; then compound 2.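

In this assay, replacing 4-fluorobenzyl with 4-methylbenzyl gives a 260-fold lower number from compound 3 to compound 4 (2.41 log units; beyond the scatter), so a single-atom exchange on this aromatic carbon, para to a large group, can move growth inhibition far beyond the scatter. Among these compounds, until this pair, no two compounds differed in one place, so this position had not been read on its own. No evidence at hand accounts for the size of this step.

Still open, as far as these compounds go, is whether the gain is specific to methyl, or whether ethyl, methoxy or chloro at this place would give a similar number. A carboxylic acid or an amine here would test how far the position tolerates very different groups.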